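Removal of the methoxy group in an oxime series

The source may report more compounds than this note shows. Statements on the series, on what has been measured and on what is new or still open speak of the compounds shown alone.

Measured compounds in a functional assay (Mus musculus, strain Balb/c) for inhibition, read by ELISA, with a stated time of 72 h; a higher number here means a weaker inhibitor, a lower number a stronger inhibitor:
Compound 1 `COc1ccc(C(/C=C/c2ccc(Br)cc2)=N/O)cc1` gives 13900 nM.
Compound 2 `COc1ccc(C(/C=C/c2cccs2)=N/O)cc1` gives 8490 nM.
Compound 3 `COc1ccc(/C=C/C(=N\O)c2ccc(OC)cc2)cc1` gives 12300 nM.

Compound 3 holds the second highest of the three numbers in this assay; compound 1 lies nearest and compound 2 furthest, yet both differences are within the scatter, so no order among the three can be read. Going by the values given here, the one single-change step measured so far, a 1.1-fold lower number from compound 1 to compound 3 (0.05 log units; within the scatter), is also within the scatter.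

Compound 4 `COc1ccc(C(/C=C/c2ccccc2)=N/O)cc1` differs from compound 3 by hydrogen in place of methoxy on an aromatic carbon. Among the compounds with values here, no measured step removes a methoxy group from this ring, so nothing directly bears on this change. Within the data shown here, the only comparison available, a 1.1-fold lower number from compound 1 to compound 3 (0.05 log units; within the scatter), shows that a change at that same ring position left the number essentially unchanged.

Compound 4 is therefore expected to remain close to compound 3, with an estimated step of a 1.0-fold lower number from compound 3 to compound 4 (0.01 log units; within the scatter) in this assay. The estimate for compound 4 is 12000 nM, with a range from 5000 nM to 30000 nM.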

Compound 4, half-maximal inhibitory concentration: 11800 nM
Estimate against measurement, compound 4: 1.0-fold (0.01 log units) above, and the stated range covers the measured number.
By their numbers in this assay, from the lowest: compounds 2, 4, 3 and 1 (each within the scatter of the next).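

In this assay, the position para to a large group now has a direct reading for loss of methoxy, with a 1.0-fold lower number from compound 3 to compound 4 (0.02 log units; within the scatter) showing no readable change when hydrogen replaces that group. The bromo comparison agrees, with a 1.2-fold lower number from compound 1 to compound 4 (0.07 log units; within the scatter) for hydrogen in place of bromo on an aromatic carbon, so hydrogen, methoxy and bromo at this position are not separated by these numbers. Phenyl in place of thiophen-2-yl gives a 1.4-fold higher number from compound 2 to compound 4 (0.14 log units; within the scatter) and is likewise within the scatter, so this change at the end of the chain also separates nothing among these compounds.

Going by these compounds, whether an amine or a carboxylic acid at this position, or a longer chain there, would move the number beyond the scatter remains open. No evidence is available to account for how closely these numbers lie.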